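Fluoro for hydrogen on a quinoline-type core toward CRF1 antagonism

The source may report more compounds than this note shows. Statements on the series, on what has been measured and on what is new or still open speak of the compounds shown alone.

Measured compounds:
compound 1 `CCC(CC)Nc1ccc(C)c2nc(-c3c(OC)cc(COC)cc3OC)c(C)cc12` — "not determined" (no result reported)
compound 2 `CCN(CC)c1ccc(C)c2nc(-c3c(OC)cc(COC)cc3OC)ccc12` — 381 nM

Among the compounds with values here, compound 2 `CCN(CC)c1ccc(C)c2nc(-c3c(OC)cc(COC)cc3OC)ccc12` is the only compound here with a number: in a functional assay on HEK293 cells for antagonist activity at corticotropin-releasing factor receptor 1 (Homo sapiens), read by cAMP accumulation and immunoassay, with a stated time of 30 min (on this read-out lower numbers stand for stronger inhibition and higher numbers for weaker inhibition), compound 2 gives 381 nM. Compound 1 `CCC(CC)Nc1ccc(C)c2nc(-c3c(OC)cc(COC)cc3OC)c(C)cc12` belongs to the same series, but in this assay compound 1 gives "not determined" (no result reported), so nothing can be said about how its values compare with those of compound 2.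

The step to compound 3 `CCN(CC)c1ccc(C)c2nc(-c3c(OC)cc(COC)cc3OC)c(F)cc12` is a single exchange: fluoro in place of hydrogen on an aromatic carbon. The fluorine goes onto an aromatic carbon of the six-membered ring with one nitrogen, ortho to a large group and two atoms from the ring nitrogen. Within the data shown here, no comparable exchange is available among the measured compounds, so there is no measured step to lean on. A small replacement of this kind, with one heavy atom entering and no donors or acceptors added, is expected to move the result in this assay little, most likely not beyond the usual scatter, and if anything toward somewhat stronger inhibition.

On that basis compound 3 is estimated at 260 nM, within a range of 80 nM to 850 nM; the step of a 1.5-fold lower number from compound 2 to compound 3 (0.17 log units; within the scatter) is the change this estimate implies.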

Compound 3, half-maximal inhibitory concentration: 131 nM
Beside the measured number, compound 3's estimate is 2.0-fold (0.30 log units) above it; the range from low to high includes it.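

In this assay, fluoro in place of hydrogen gives a 2.9-fold lower number from compound 2 to compound 3 (0.46 log units; beyond the scatter), so a single fluorine on this aromatic carbon, ortho to a large group and two atoms from the ring nitrogen, moves the result beyond the usual scatter and toward stronger inhibition. Within the data shown here, the earlier compounds offered only one number and no measured step, so this is the first sign that the series responds to a change at this position, although it rests on one pair of compounds. Nothing given here accounts for the lower number.

On these data alone, it remains open whether this shift belongs to fluoro in particular or would also appear with chloro, a nitrile or a methoxy group on the same aromatic carbon. As far as these compounds go, it is also open whether the step would carry over to a core bearing another amine in place of the diethylamino group, such as a pyrrolidine or a morpholine, since compound 1 differs from compound 3 in more than one place and has no reported result.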